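The source may hold more compounds than are shown below. What is called first, only, known or untested is meant among the compounds shown, and "the series" means these compounds.

In a functional assay on OVCAR-3 cells (Homo sapiens) for inhibition, read by MTT assay, with a stated time of 24 h (a lower number here means a stronger inhibitor, a higher number a weaker inhibitor), three compounds sharing one core have been measured. Compound 1 `CC1(C)[C@H]2CC[C@]1(C)N(Cc1cn(-c3cccc(F)c3)nn1)C(=O)C2` gives 430 nM, compound 2 `CC1(C)[C@H]2CC[C@]1(C)N(Cc1cn(-c3cccc(C#N)c3)nn1)C(=O)C2` gives 230 nM, and compound 3 `CC1(C)[C@H]2CC[C@]1(C)N(Cc1cn(-c3ccccc3)nn1)C(=O)C2` gives 50 nM. That is the lowest number of the three, and its steps to both others lie beyond the scatter, so compound 3 is the strongest inhibitor so far. Compound 4 `COc1cccc(-n2cc(CN3C(=O)C[C@@H]4CC[C@@]3(C)C4(C)C)nn2)c1` has not yet been measured. Its difference from compound 3 is methoxy in place of hydrogen on an aromatic carbon, meta to a large group.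

The closest evidence comes from two steps that swap a group for hydrogen on an aromatic carbon: hydrogen in place of fluoro gives an 8.6-fold lower number from compound 1 to compound 3 (0.93 log units; beyond the scatter), and hydrogen in place of cyano gives a 4.6-fold lower number from compound 2 to compound 3 (0.66 log units; beyond the scatter). Both are modest but beyond the scatter. Fluoro and cyano themselves differ only within the scatter, at a 1.9-fold lower number from compound 1 to compound 2 (0.27 log units; within the scatter). Neither group is methoxy, so this is only a rough guide, but a move to a higher number of similar size is expected in this assay. The expected change is a 4.0-fold higher number from compound 3 to compound 4 (0.60 log units; beyond the scatter). The estimated value for compound 4 is 200 nM, with an expected range from 60 nM to 600 nM.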

Compound 4, half-maximal inhibitory concentration: 280 nM
Estimate against measurement, compound 4: 1.4-fold (0.15 log units) below; low and high end bracket the measured number.
By their numbers in this assay, from the lowest: compound 3; then compounds 2, 4 and 1 (each within the scatter of the next).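

Methoxy in place of hydrogen gives a 5.6-fold higher number from compound 3 to compound 4 (0.75 log units; beyond the scatter) and so joins fluoro and cyano: all three groups at this position, meta to a large group, give a higher number than hydrogen, and compound 3 remains the strongest inhibitor of the four. Methoxy cannot be separated from the other two, with cyano to methoxy giving a 1.2-fold higher number from compound 2 to compound 4 (0.09 log units; within the scatter) and fluoro to methoxy giving a 1.5-fold lower number from compound 1 to compound 4 (0.19 log units; within the scatter) so that, across these compounds, replacing the hydrogen matters more than which of the three groups replaces it. Nothing available explains why these replacements raise the number.

On these data alone, whether any group at this position can give a lower number than hydrogen remains open, as does the effect of an amine or a carboxylic acid here. As far as these compounds go, it is also open whether methoxy on another carbon of the ring would behave the same way.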